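Swapping Chloro for Methyl in a Small Thioether Series

This account rests on a few compounds, and the source may have more. Where it says the series, first, only, none or still open, it means among the compounds named here.

Measured so far:
Compound 1, `Cc1ccccc1Sc1cccc(N)c1C#N`, in a functional assay on MT4 cells (Homo sapiens) for cytotoxicity (a lower number here means a stronger inhibitor, a higher number a weaker inhibitor), gives > 40000 nM, which is a limit of the assay and not a number.
Compound 2, `N#Cc1c(N)cccc1Sc1ccccc1Cl`, in this assay gives 33000 nM.
Compound 3, `N#Cc1c(N)cccc1Sc1cc(Cl)cc(Cl)c1`, in this assay gives 3000 nM.

Compound 4, `Cc1cc(Cl)cc(Sc2cccc(N)c2C#N)c1`, is the one still to be measured in this assay. It differs from compound 3 in a single place: methyl in place of chloro on an aromatic carbon. The same kind of change has been made once before, from compound 2 to compound 1: methyl in place of chloro on an aromatic carbon. The surroundings are not the same: in compound 1 the methyl sits ortho to a large group, whereas in compound 4 it sits meta to a chloro group (1 heavy atom) and meta to a large group. The earlier step was an at least 1.2-fold higher number from compound 2 to compound 1 (0.08 log units; that floor lies within the scatter), and its floor comes from the limit of > 40000 nM in this assay, at which 1 of the 3 values shown sits. How the core of compound 3 differs from that of compound 2 is not broken down here; the two values simply show compound 3 giving the lower number.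

For compound 4 a similar small rise in the number is expected, a 2.0-fold higher number from compound 3 to compound 4 (0.30 log units; within the scatter). This expectation rests on the earlier step, an at least 1.2-fold higher number from compound 2 to compound 1 (0.08 log units; that floor lies within the scatter), which gives little reason to expect a large move in either direction. Compound 4 is therefore estimated at 6000 nM.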

Compound 4, half-maximal inhibitory concentration: 16000 nM
Estimate against measurement, compound 4: 2.7-fold (0.43 log units) below; measured number inside the range.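

On the core of compound 3, methyl in place of chloro gives a 5.3-fold higher number from compound 3 to compound 4 (0.73 log units; beyond the scatter) in this assay, so here the swap moves the number by more than ordinary repeat-to-repeat variation. This one result does not show that the change has the same size on every core, and the two cores seen so far cannot be said to respond either alike or differently: the same change on two cores in this assay, an at least 1.2-fold higher number (0.08 log units; that floor lies within the scatter) from compound 2 to compound 1 and a 5.3-fold higher number (0.73 log units; beyond the scatter) from compound 3 to compound 4; the limit leaves it open whether they differ
Compound 1 gives > 40000 nM, which is a limit of the assay and not a number.

The compounds shown carry only chloro or methyl at the changed place, so it remains open how a fluoro, a methoxy or an ethyl group would behave there. Also open, from the compounds shown here alone, is whether the swap would give a step of similar size on a third core, or on a version of the earlier core whose value could be read as a number.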